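Third arrangement of a chloropyridinyl group on a shared core

The compounds below may be only part of what the source reports. "The series", "measured", "known", "first", "only" and "open" are said of these compounds alone.

Compound 1 `COc1cc(C(=O)N2CCC(O)C(C)C2)cc2nc(NCc3cncc(Cl)c3)oc12`: 7200 nM
Compound 2 `COc1cc(C(=O)N2CCC(O)C(C)C2)cc2nc(NCc3ccnc(Cl)c3)oc12`: 6900 nM

For the measured compounds named here, in an assay on isolated protein for inhibition of thyroid hormone receptor beta (Homo sapiens), read by fluorescence, with a stated time of 30 min (on this read-out lower numbers stand for stronger inhibition and higher numbers for weaker inhibition), compound 2 gives 6900 nM, and its one neighbour, compound 1, lies within the scatter of it. Compound 3 `COc1cc(C(=O)N2CCC(O)C(C)C2)cc2nc(NCc3cccc(Cl)n3)oc12` carries the change (6-chloropyridin-2-yl in place of 2-chloropyridin-4-yl on a saturated chain carbon bound to a nitrogen on an aromatic ring). Going by the values given here, the only step that bears on this, a 1.0-fold lower number from compound 1 to compound 2 (0.02 log units; within the scatter), also rearranged the same group on the same carbon and left the number essentially unchanged. Compound 3 is therefore expected to show no step beyond the scatter, a 1.0-fold higher number from compound 2 to compound 3 (0.01 log units; within the scatter). The estimate for compound 3 is 7000 nM, within 3000 nM to 17000 nM.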

Compound 3, half-maximal inhibitory concentration: 580 nM
Compound 3: the middle estimate sits 12-fold (1.08 log units) above what was measured; the whole stated range lies above it.
By their numbers in this assay, from the lowest: compound 3; then compounds 2 and 1 (each within the scatter of the next).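

In this assay the 6-chloropyridin-2-yl group gives a 12-fold lower number from compound 2 to compound 3 (1.08 log units; beyond the scatter) and a 12-fold lower number from compound 1 to compound 3 (1.09 log units; beyond the scatter) on the same saturated chain carbon, with the same atoms and the same counts of donors and acceptors. The earlier pair suggested that this position did not respond to rearranging the chloropyridinyl group, but compound 3 shows that it can. Nothing available explains the difference.

Going by these compounds, it remains open whether the chlorine of the 6-chloropyridin-2-yl group is needed. A methyl, a methoxy or a fluorine in its place would test this.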